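The compounds below may be only part of what the source reports. "The series", "measured", "known", "first", "only" and "open" are said of these compounds alone.

The measured compounds:

Compound 1 `COc1ccc(NC(=O)[C@H]2CCCN2C(=O)C(C)(C)c2ccc(Cl)cc2)cc1`: in an assay on isolated protein for inhibition of histone acetyltransferase p300 (Homo sapiens), with a stated time of 60 min (a higher number here means a weaker inhibitor, a lower number a stronger inhibitor), compound 1 gives 50.1 nM.
Compound 2 `O=C(Nc1ccc2[nH]ncc2n1)[C@H]1CCCN1C(=O)C1(c2cccc(Cl)c2)CCCC1`: in this assay compound 2 gives 0.159 nM.
Compound 3 `O=C(Nc1ccc2[nH]ncc2n1)[C@H]1CCCN1C(=O)C1(c2ccc(Cl)cc2)CCC1`: in this assay compound 3 gives 0.1 nM.

Compound 2 holds the second highest of the three numbers. Its nearest neighbour is compound 3, whose number lies lower by an amount within the scatter, so the two cannot be put in order. Compound 1 stands far from it, with a much higher number that lies well beyond the scatter, and is clearly the weaker of the pair.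

The step under consideration leads to compound 4 `O=C(Nc1ccc2[nH]ncc2c1)[C@H]1CCCN1C(=O)C1(c2cccc(Cl)c2)CCCC1`. The change is a group of 9 heavy atoms (7 carbon, 2 nitrogen; one five-membered aromatic ring with 2 hetero atoms, one six-membered aromatic ring of carbon only) in place of a group of 9 heavy atoms (6 carbon, 3 nitrogen; one five-membered aromatic ring with 2 hetero atoms, one six-membered aromatic ring with 1 hetero atom), on an amide-type nitrogen. For the measured compounds named here, no pair among the measured compounds differs in this single place, so the size of the step has no direct precedent here; the three measured numbers only show that the shared core tolerates large changes at the other end of the molecule while the aromatic amide group has stayed constant for the two most potent compounds.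

The step is expected to be a modest weakening, no larger than a 5.0-fold higher number from compound 2 to compound 4 (0.70 log units; beyond the scatter). Compound 4 is therefore estimated at 0.8 nM, within a range from 0.15 nM to 5 nM.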

Compound 4, half-maximal inhibitory concentration: 1 nM
The estimate for compound 4 lay 1.3-fold (0.10 log units) below the measured number, and the stated range covers the measured number.
By their numbers in this assay, from the lowest: compounds 3 and 2 (each within the scatter of the next); then compound 4; then compound 1.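

In this assay, placing 1H-indazol-5-yl on the amide-type nitrogen of compound 2 gives a 6.3-fold higher number from compound 2 to compound 4 (0.80 log units; beyond the scatter), the only step shown at this place with the rest of the molecule held constant. It shows that this place responds to a small change: the two groups have the same number of heavy atoms and the same ring sizes, and the entering group differs by having one carbon in place of one nitrogen, a six-membered aromatic ring of carbon only and one hydrogen-bond acceptor fewer, yet the step lies beyond the scatter, although it is modest and compound 4 still gives 1 nM. Nothing measured here bears on what lies behind this shift, so the step stands as an observation only.

The compounds shown leave open whether the same exchange would have a similar size with the other end of the molecule as it stands in compound 3. They also leave open how a plain phenyl or an aminopyridine group on the same amide-type nitrogen would compare with the two groups seen here.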